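Swapping a Chain Amine for a Ring Amide: Expected Cytotoxicity

A few compounds are considered here, and "the series" means these few. Any claim that something is new, unique, unknown or untested is made for them only; others in the source may bear on it.

Measured compounds:
compound 1 `CC1=NN(S(=O)(=O)c2ccc([N+](=O)[O-])cc2)C(c2cc(Cl)ccc2O)C1` — "not active" (no number reported)
compound 2 `CCCNCC(=O)N1N=C(c2cc3ccccc3oc2=O)CC1c1ccccc1` — 10800 nM
compound 3 `NC(=O)C1CCN(CC(=O)N2N=C(c3cc4ccccc4oc3=O)CC2c2ccccc2)CC1` — not yet measured

Of the compounds shown here, two have been tested in a functional assay on HepG2 cells (Homo sapiens) for cytotoxicity, read by MTT assay, with a stated time of 48 h; a lower number here means a stronger inhibitor, a higher number a weaker inhibitor. Compound 1 is recorded there as "not active" (no number reported), with no number attached. Within the data shown here, compound 2 gives 10800 nM, and so it stands as the only compound with a single number in this assay; it cannot be ranked against compound 1, whose result carries no number. Among the measured compounds shown here, because compound 1 and compound 2 do not differ in just one place, no step between measured compounds is available.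

Compound 3 is reached from compound 2 by one change: 4-carbamoylpiperidin-1-yl in place of propylamino on a saturated chain carbon bound to a carbonyl carbon. The shared core of compound 2 and compound 3 is otherwise kept, and the change sits at the far end of the side chain that hangs from the carbonyl.

For the measured compounds named here, with no measured step to lean on, the expectation rests on compound 2 alone. The step of a 1.1-fold higher number from compound 2 to compound 3 (0.05 log units; within the scatter) is expected to be small, if anything toward a weaker inhibitor, and within the usual scatter. Compound 3 is therefore estimated at 12000 nM, with a range from 4000 nM to 40000 nM.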

Compound 3, half-maximal inhibitory concentration: 19300 nM
Compound 3: middle estimate off by 1.6-fold (0.21 log units), on the low side, within the range that was stated.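

Among these compounds, this is the first step that can be read at this position. On a saturated chain carbon bound to a carbonyl carbon, 4-carbamoylpiperidin-1-yl in place of propylamino gives a 1.8-fold higher number from compound 2 to compound 3 (0.25 log units; within the scatter) in this assay and so leaves the two readings within the usual scatter, even though the entering group has 9 heavy atoms against 4 and brings a six-membered non-aromatic ring where the chain had no ring. The data shown here offer no explanation for this result.

Among the compounds shown here, the single step changes the ring and the carbamoyl group together, so it cannot show what each contributes alone; piperidin-1-yl without the carbamoyl group, or a carboxylic acid in its place, would separate the two. As far as these compounds go, it also remains open whether the side chain matters at all for the reading in this cell assay, since both values come from compounds sharing the same core, and a comparison with a plain primary amine at this place would test how far the reading depends on the group at the end of the chain.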